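The source may report more compounds than this note shows. Statements on the series, on what has been measured and on what is new or still open speak of the compounds shown alone.

Working notes on the series. Of the compounds shown here, three have been read so far in a functional assay on the whole organism (strain Kunming) with Mus musculus as the target, with a stated time of 0.5 h (on this read-out lower numbers stand for an effect already at smaller amounts and higher numbers for an effect only at larger amounts of compound), and none of them has yet given a number. Compound 1 (`COc1cc(OC)c(OC)cc1/C=C/COC(=O)/C=C/c1c(OC)ccc(OC)c1OC`) gives > 674 umol/kg as a limit of the assay. Compound 2 (`COc1cc(OC)c(OC)cc1/C=C/COC(=O)/C=C/c1cc(OC)c(OC)c(OC)c1OC`) gives > 421 umol/kg as a limit too. Compound 3 (`COc1cc(OC)c(OC)cc1/C=C/COC(=O)/C=C/c1ccc(Br)cc1`) gives > 692 umol/kg as a limit as well. Compound 3 therefore stands alongside the other two with no measured number, and no order among the three can be read from these results.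

The next compound is compound 4 (`COc1cc(OC)c(OC)cc1/C=C/COC(=O)/C=C/c1cccc(Br)c1`), which has the same atoms as compound 3, joined differently. The change is 3-bromophenyl in place of 4-bromophenyl on a double-bonded chain carbon bound to a double-bonded chain carbon and amounts to 3-bromophenyl in place of 4-bromophenyl on a double-bonded chain carbon bound to a double-bonded chain carbon. For the measured compounds named here, the series holds no measured step between two compounds that could size this change. The expectation therefore rests on compound 3 alone, with its limit of > 692 umol/kg as the only anchor. The estimated at least 1.0-fold lower number from compound 3 to compound 4 (0.02 log units; that floor lies within the scatter) is expected to stay within the usual scatter, with no direction favoured. Another limit is the likeliest report. For compound 4 the expected value is 650 umol/kg in this assay with an estimated range of 250 umol/kg to 1000 umol/kg for any number obtained.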

Compound 4, dose for half-maximal effect: 497 umol/kg
For compound 4 the middle estimate is 1.3-fold (0.12 log units) above the measured one; the range from low to high includes it.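

In this assay compound 4 is the only compound shown to give a number rather than a limit, so 3-bromophenyl in place of 4-bromophenyl on a double-bonded chain carbon bound to a double-bonded chain carbon is the one change here that yields a readable value. This change gives an at least 1.3-fold lower number from compound 3 to compound 4 (0.14 log units; that floor lies within the scatter) and that figure is only a floor, which on its own does not set the pair apart from the scatter. The value of compound 3 is a limit of the assay, so the true size of the step cannot be read, and the floor rests on that limit: the limit of > 692 umol/kg in this assay, at which 1 of the 4 values shown sits.

On these data alone, the real gap within this pair stays unknown until compound 3 gives a number, and a single pair of bromophenyl isomers cannot support any trend for this position. Also open, as far as these compounds go, is how this read-out responds when the bromine of 3-bromophenyl gives way to a chlorine, an amine or a carboxylic acid, or when the ester of the shared core gives way to an amide.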